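A few compounds are considered here, and "the series" means these few. Any claim that something is new, unique, unknown or untested is made for them only; others in the source may bear on it.

Compound 1 `Cc1cccc2c1nc(COc1ccc(Cl)cc1)n2CCCC1CCN(CC(=O)O)CC1` carries a carboxymethyl group on the amine nitrogen of its ring. Among the measured compounds shown here, in an assay on AV12 cells for binding affinity to Neuropeptide Y receptor type 1 (Homo sapiens) (a lower number here means a stronger inhibitor, a higher number a weaker inhibitor), compound 1 gives 2190 nM, the weakest number of the two compounds measured so far, and one further entry for compound 1 reports no single number. Compound 2 `Cc1cccc2c1nc(COc1ccc(Cl)cc1)n2CCCC1CCN(CCCCN2CCCCC2)CC1` bears a different group on that same nitrogen, and in this assay compound 2 gives 52 nM; 5.7 nM (2 entries). The repeated entries for compound 2 (the several entries of compound 2 in this assay, 52 nM; 5.7 nM (2 entries)) show how widely repeats of such a measurement can spread.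

Compound 3 `Cc1cccc2c1nc(COc1ccc(Cl)cc1)n2CCCC1CCN(C(=O)CCN2CCCCC2)CC1` has not been measured. It differs from compound 1 by (2-(piperidin-1-yl)ethyl)carbonyl in place of carboxymethyl on an amine nitrogen in a ring. The step from compound 1 to compound 3 is expected to be a 15-fold lower number from compound 1 to compound 3 (1.16 log units; beyond the scatter), a gain well beyond the usual scatter, since the carboxylic acid goes away. In this assay compound 3 is expected to give about 150 nM, with a likely range from 30 nM to 800 nM.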

Compound 3, inhibition constant: 260 nM
The estimate for compound 3 lay 1.7-fold (0.24 log units) below the measured number; low and high end bracket the measured number.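

In this assay, putting (2-(piperidin-1-yl)ethyl)carbonyl in place of carboxymethyl on this amine nitrogen in a ring gives an 8.4-fold lower number from compound 1 to compound 3 (0.93 log units; beyond the scatter), so the group held here clearly moves the binding number. The change is not a single one, though: the hydrogen-bond donor of carboxymethyl leaves, while a carbonyl stays and a six-membered non-aromatic ring enters, and one step cannot separate these parts. Compound 3, at 260 nM, still gives a higher number than either entry of compound 2, whose repeats themselves lie far apart: the several entries of compound 2 in this assay, 52 nM; 5.7 nM (2 entries)

Which part of the new group carries the gain remains open. A simple acetyl group, a longer chain leading to the piperidine ring, or a morpholine ring in place of piperidine would each test a different part.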